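This account rests on a few compounds, and the source may have more. Where it says the series, first, only, none or still open, it means among the compounds named here.

For the measured compounds named here, in a functional assay on U-373MG ATCC cells (Homo sapiens) for inhibition, read by MTT assay, with a stated time of 72 h (a higher number here means a weaker inhibitor, a lower number a stronger inhibitor), compound 2 `CC1(C)CC(NC(=S)Nc2cccc([N+](=O)[O-])c2)c2cc(Br)ccc2O1` gives 4000 nM, the lower of the two numbers known so far, and the gap to compound 1 `CC1(C)CC(NC(=S)Nc2cccc(C#N)c2)c2cc(F)ccc2O1`, which gives 30000 nM, lies beyond the scatter. Compound 3 `CC1(C)CC(NC(=S)Nc2cccc([N+](=O)[O-])c2)c2cc(F)ccc2O1` differs from compound 2 in one place: fluoro in place of bromo on an aromatic carbon. Going by the values given here, no measured pair isolates this change. Compound 1 also carries fluoro and gives 30000 nM, so a move to a higher number, beyond the scatter, is expected in this assay. The estimated change is a 3.0-fold higher number from compound 2 to compound 3 (0.48 log units; beyond the scatter). For compound 3 the expected value is 12000 nM, within an estimated range of 4500 nM to 30000 nM.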

Compound 3, half-maximal inhibitory concentration: 6000 nM
The estimate for compound 3 lay 2.0-fold (0.30 log units) above the measured number; the range from low to high includes it.
By their numbers in this assay, from the lowest: compounds 2 and 3 (each within the scatter of the next); then compound 1.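

In this assay, fluoro in place of bromo on an aromatic carbon gives a 1.5-fold higher number from compound 2 to compound 3 (0.18 log units; within the scatter), so this exchange at this position does not separate the two compounds. The larger difference comes with nitro in place of cyano on an aromatic carbon, which gives a 5.0-fold lower number from compound 1 to compound 3 (0.70 log units; beyond the scatter). Nothing available explains either step. As far as these compounds go, whether a chloro or methyl group on the same carbon would also stay within the scatter remains open, as does how an amine or a carboxylic acid in place of nitro would read.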